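Three Chromene Chalcones at the Limit, a Fourth Awaited

This account rests on a few compounds, and the source may have more. Where it says the series, first, only, none or still open, it means among the compounds named here.

Measured compounds:
Compound 1, `COc1ccc(C(=O)/C=C/c2ccc(-c3ccccc3)cc2)c2c1C=CC(C)(C)O2`, in a functional assay on HT-29 cells (Homo sapiens) for antiproliferative activity, read by MTT assay, with a stated time of 24 h (a higher number here means a weaker inhibitor, a lower number a stronger inhibitor), compound 1 gives > 10000 nM, a limit of the assay.
Compound 2, `COc1ccc(C(=O)/C=C/c2ccc(OC)c(OC)c2OC)c2c1C=CC(C)(C)O2`, in this assay compound 2 gives > 10000 nM, also a limit.
Compound 3, `COc1ccc(C(=O)/C=C/c2ccsc2)c2c1C=CC(C)(C)O2`, in this assay compound 3 gives > 10000 nM, again a limit.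

Compound 3 thus stands where every measured compound stands: the limit of > 10000 nM in this assay, at which 3 of the 3 values shown sit. No numerical value separates it from compound 1 or compound 2, so nothing can be said of order among the three.

Compound 4, `COc1ccc(C(=O)/C=C/c2cc(Cl)ccc2O)c2c1C=CC(C)(C)O2`, has not yet been measured in this assay. It differs from compound 3 in one place: 5-chloro-2-hydroxyphenyl in place of thiophen-3-yl on a double-bonded chain carbon bound to a double-bonded chain carbon.

For the measured compounds named here, with no measured step between any two compounds, the direction and size of a step that the limit leaves unreadable from compound 3 to compound 4 are expected only loosely; the expectation is that compound 4 most probably also returns a limit, with some chance that a number appears. For compound 4 the estimate in this assay is 12000 nM, with a range from 2500 nM to 50000 nM.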

Compound 4, half-maximal inhibitory concentration: 4970 nM
Beside the measured number, compound 4's estimate is 2.4-fold (0.38 log units) above it; measured number inside the range.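

Putting 5-chloro-2-hydroxyphenyl in place of thiophen-3-yl on a double-bonded chain carbon bound to a double-bonded chain carbon gives an at least 2.0-fold lower number from compound 3 to compound 4 (0.30 log units; that floor lies within the scatter) in this assay. Compound 3 holds only a limit, so this step has a floor and no known full size. Compound 4 is the only one of the four with a number rather than a limit, which shows that a change at this position can bring a readable value on the shared core: the limit of > 10000 nM in this assay, at which 3 of the 4 values shown sit.

The compounds shown do not separate the part played by the chlorine from that of the hydroxyl in 5-chloro-2-hydroxyphenyl. They also leave open how this position would read with an amine in place of the hydroxyl or a bromine in place of the chlorine.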